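Removing the trifluoromethyl group from compound 3

A few compounds are considered here, and "the series" means these few. Any claim that something is new, unique, unknown or untested is made for them only; others in the source may bear on it.

Measured in a functional assay on ECa-109 cells for inhibition, with ECa-109 cell line (Homo sapiens) as the target, read by sulforhodamine B assay (a higher number here means a weaker inhibitor, a lower number a stronger inhibitor), so far:
compound 1 (`O=C1C=C(Nc2ccccc2F)C(=O)c2c1nc1n2[C@H]2OC[C@@H](O)[C@H]2OC1`) gives 2760 nM
compound 2 (`O=C1C=C(NC2CCCC2)C(=O)c2c1nc1n2[C@H]2OC[C@@H](O)[C@H]2OC1`) gives > 16000 nM
compound 3 (`O=C1C=C(Nc2ccc(C(F)(F)F)cc2)C(=O)c2c1nc1n2[C@H]2OC[C@@H](O)[C@H]2OC1`) gives 5500 nM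

The entry for compound 2 at > 16000 nM is a limit of the assay and not a number. Compound 3 at 5500 nM has compound 1 as its nearest neighbour at 2760 nM and the two lie within the scatter of each other, so they cannot be ranked.

Compound 4 (`O=C1C=C(Nc2ccccc2)C(=O)c2c1nc1n2[C@H]2OC[C@@H](O)[C@H]2OC1`) has hydrogen in place of trifluoromethyl on an aromatic carbon, which turns 4-(trifluoromethyl)phenyl into phenyl (hydrogen in place of trifluoromethyl on an aromatic carbon). Among the compounds with values here, no measured step makes exactly this change. The closest guide is the exchange of one substituted phenyl for another on the amine nitrogen, a 2.0-fold higher number from compound 1 to compound 3 (0.30 log units; within the scatter) and this stayed within the scatter. The steps that bring in cyclopentyl are larger, an at least 5.7-fold higher number from compound 1 to compound 2 (0.76 log units; beyond the scatter) and an at least 2.9-fold lower number from compound 2 to compound 3 (0.46 log units; beyond the scatter) but compound 4 keeps a phenyl on that nitrogen. No step beyond the scatter is therefore expected in this assay and the expected change is a 1.4-fold lower number from compound 3 to compound 4 (0.16 log units; within the scatter) in the direction of a somewhat lower number. The estimated value for compound 4 is 3800 nM with an expected range of 1600 nM to 9000 nM.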

Compound 4, half-maximal inhibitory concentration: 4970 nM
Beside the measured number, compound 4's estimate is 1.3-fold (0.12 log units) below it, and the stated range covers the measured number.
By their numbers in this assay, from the lowest: compounds 1, 4 and 3 (each within the scatter of the next). At a limit, above all of these: compound 2.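

In this assay, the trifluoromethyl group on the aromatic carbon proves dispensable, a 1.1-fold lower number from compound 3 to compound 4 (0.04 log units; within the scatter), and taking the fluoro off the phenyl ring gives the same picture, a 1.8-fold higher number from compound 1 to compound 4 (0.26 log units; within the scatter), so compounds 1, 3 and 4 cannot be ranked and neither substituent is shown to matter for the reading. Compound 4 also shows that an unsubstituted phenyl on the amine nitrogen is enough to separate this series from the cyclopentyl analogue, an at least 3.2-fold lower number from compound 2 to compound 4 (0.50 log units; beyond the scatter), so the difference seen earlier does not depend on any substituent on the phenyl ring. The size of that step is only a lower bound, as compound 2 stands at a limit of the assay and not at a number: the limit of > 16000 nM in this assay, at which 1 of the 4 values shown sits.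

The compounds shown leave open whether a methoxy group, an amine or a carboxylic acid on that same aromatic carbon would move the number beyond the scatter, as the trifluoromethyl and hydrogen compounds do not. They also leave open whether a benzyl group or a pyridine ring on the amine nitrogen would read like the phenyl compounds or like the cyclopentyl compound.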